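The source may report more compounds than this note shows. Statements on the series, on what has been measured and on what is new or still open speak of the compounds shown alone.

Working notes on the series.

Three analogues of the shared core have been measured in a functional assay on RAW264.7 cells (Mus musculus) for inhibition; a higher number here means a weaker inhibitor, a lower number a stronger inhibitor. Compound 1 `O=C1/C(=C/c2cccnc2)CCc2c(O)cccc21` gives 2950 nM in this assay. Compound 2 `O=C1/C(=C/c2ccccc2F)CCc2cc(O)ccc21` gives 1740 nM in this assay. Compound 3 `O=C1/C(=C/c2ccc(OC(F)(F)F)cc2)CCc2cc(O)ccc21` gives 1350 nM in this assay. The three numbers sit close together: the gap between compound 2 and compound 3 and the gap between compound 2 and compound 1 are both within the usual scatter of repeated measurements, so none of the three can be called stronger or weaker than another on the present numbers.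

Compound 4 `O=C1/C(=C/c2ccccc2Br)CCc2cc(O)ccc21` has not yet been measured in this assay. It differs from compound 2 by bromo in place of fluoro on an aromatic carbon. For the measured compounds named here, no pair of measured compounds shows this change, so there is no step from which to read its size. The expectation for the step from compound 2 to compound 4 is a 1.2-fold lower number from compound 2 to compound 4 (0.09 log units; within the scatter), which is no more than the scatter allows, with the direction left open. On that basis compound 4 is estimated at 1400 nM in this assay, with a range from 600 nM to 3500 nM expected to cover most repeat measurements.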

Compound 4, half-maximal inhibitory concentration: 1070 nM
For compound 4 the middle estimate is 1.3-fold (0.12 log units) above the measured one; the measured number falls inside the stated range.
By their numbers in this assay, from the lowest: compounds 4, 3, 2 and 1 (each within the scatter of the next, the first and the last beyond it).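

In this assay the series now has its first readable step: a 1.6-fold lower number from compound 2 to compound 4 (0.21 log units; within the scatter) for bromo in place of fluoro on an aromatic carbon, ortho to a large group. At this position, a fluorine and a bromine therefore cannot be told apart on the present numbers, even though one heavy atom of one halogen is exchanged for one of the other and neither group brings a hydrogen-bond donor, an acceptor or a net charge. No measurement at hand bears on what lies behind this result.

Going by these compounds, the two compounds show only two halogens at this place, so it stays open whether a methoxy group, an amine or a carboxylic acid there would give a step beyond the scatter. Also open, on these data alone, is whether bromo in place of fluoro would give a step of similar size on the differently substituted core of compound 1, since one pair on a single background cannot show how far the result carries.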